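The source may report more compounds than this note shows. Statements on the series, on what has been measured and on what is new or still open speak of the compounds shown alone.

Measured in a functional assay on MCF7 cells (Homo sapiens) for cytotoxicity; a lower number here means a stronger inhibitor, a higher number a weaker inhibitor:
compound 1 `CS(=O)(=O)c1ccc2nc(NC(=O)CCCCCCC(=O)NO)sc2c1`: 15.4 ug/mL
compound 2 `CS(=O)(=O)c1ccc2nc(NC(=O)CCCCC(=O)NO)sc2c1`: > 30 ug/mL (a limit of the assay)
compound 3 `Cc1ccc2nc(NC(=O)CCCCC(=O)NO)sc2c1`: 4.27 ug/mL

Of the two actual numbers, compound 1 holds the higher, with compound 3 lower by a margin beyond the scatter. Compound 4 `O=C(CCCCCCC(=O)Nc1nc2ccc([N+](=O)[O-])cc2s1)NO` differs from compound 1 by nitro in place of methylsulfonyl on an aromatic carbon. The closest evidence is an at least 7.0-fold lower number from compound 2 to compound 3 (0.84 log units; beyond the scatter), where methyl replaces methylsulfonyl on an aromatic carbon. The chain step an at least 1.9-fold higher number from compound 1 to compound 2 (0.28 log units; that floor lies within the scatter) does not touch this position. Nitro is not methyl, so only the direction carries over, and at reduced size. The expected change is a 1.9-fold lower number from compound 1 to compound 4 (0.28 log units; within the scatter), a small step towards a lower number that may stay within the scatter. For compound 4 the estimated value is 8 ug/mL, with an expected range from 2.5 ug/mL to 25 ug/mL.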

Compound 4, half-maximal inhibitory concentration: 3.83 ug/mL
Compound 4: middle estimate off by 2.1-fold (0.32 log units), on the high side; the measured number falls inside the stated range.
By their numbers in this assay, from the lowest: compounds 4 and 3 (each within the scatter of the next); then compound 1. At a limit, above all of these: compound 2.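

At this aromatic carbon, leaving methylsulfonyl can now be read between two actual numbers in this assay, as a 4.0-fold lower number from compound 1 to compound 4 (0.60 log units; beyond the scatter). The earlier step at this position gave only a floor, since compound 2 stands at a limit of the assay: the limit of > 30 ug/mL in this assay, at which 1 of the 4 values shown sits. The new step shows that the position also responds with the chain of compound 1, and with nitro as well as methyl in place of methylsulfonyl.

On these data alone, whether an amine or a carboxylic acid on this aromatic carbon would also give a lower number remains open, as does the effect of nitro with the chain of compound 3.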